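Removing the methyl from a methoxy group in a pyrazole series

The compounds below may be only part of what the source reports. "The series", "measured", "known", "first", "only" and "open" are said of these compounds alone.

In a functional assay on NCI-H322M cells (Homo sapiens) for cytotoxicity, read by sulforhodamine B assay, with a stated time of 48 h, tested at 10 uM (on this read-out higher numbers stand for a weaker effect at the one concentration tested and lower numbers for a stronger effect), compound 2 `COc1cc(C)cc(-c2nn(CC#N)cc2-c2ccnc(-c3ccc(N(C)C)cc3)c2)c1` gives 27%. Among the measured compounds shown here, of the two numbers measured so far it is the higher one, meaning the weaker effect. For the measured compounds named here, the only neighbour is compound 1 `Cc1cc(O)cc(-c2nn(CC#N)cc2-c2ccnc(-c3ccc(Oc4ccccc4)cc3)c2)c1`, which in this assay gives -89%, a number far lower than that of compound 2, a gap well beyond the usual scatter. Going by the values given here, compound 1 and compound 2 differ in two places at once, so no single step links them, and their two values can only be set side by side.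

Compound 3 `Cc1cc(O)cc(-c2nn(CC#N)cc2-c2ccnc(-c3ccc(N(C)C)cc3)c2)c1` has not yet been measured in this assay. It differs from compound 2 in one place: hydrogen in place of methyl on an oxygen on an aromatic ring. The change is small in size, a single carbon removed, and it leaves compound 3 with the same ring bearing a hydroxy group that compound 1 carries.

Among the compounds with values here, with no measured step of this kind to lean on, a moderate move toward a stronger effect is expected, a step of about a number 27 percentage points lower from compound 2 to compound 3 (beyond the scatter) from compound 2. Compound 3 is therefore estimated to give 0%, with a plausible range from -70% to 45%.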

Compound 3, a percentage reported as activity, at one concentration (the size of the read-out at that concentration, not a potency): -11%
For compound 3 the middle estimate is 11 percentage points above the measured one; measured number inside the range.
By their numbers in this assay, from the lowest: compound 1; then compound 3; then compound 2.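

Compound 2 and compound 1 differed in two places at once, and compound 3 now separates those two changes. In this assay, methoxy to hydroxy on the aromatic ring alone gives a number 38 percentage points lower from compound 2 to compound 3 (beyond the scatter), so this small change at this oxygen is enough to move the read-out toward a stronger effect, even though only a single carbon is lost. With the hydroxy held fixed, dimethylamino in place of phenoxy on an aromatic carbon gives a number 78 percentage points higher from compound 1 to compound 3 (beyond the scatter), so the second site also matters in its own right, and nothing available here explains either step.

The compounds shown carry only methoxy or hydroxy at this oxygen, so it stays open how a longer chain such as ethoxy, or an amine in place of the oxygen group, would read. It is also open whether the methoxy to hydroxy step would keep its direction and size with phenoxy in place of dimethylamino, as the methoxy partner of compound 1 is not among the compounds shown.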